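Adding a Chloro Group to an Anilide: What to Expect

The source may hold more compounds than are shown below. What is called first, only, known or untested is meant among the compounds shown, and "the series" means these compounds.

Compound 1 `O=C(CCCCC1CCSS1)Nc1ccccn1` and compound 2 `O=C(CCCCC1CCSS1)Nc1ccc(Cl)cn1` share one core, and compound 2 differs from compound 1 by chloro in place of hydrogen on an aromatic carbon. In a functional assay on Bel-7402 cells (Homo sapiens) for inhibition, read by MTT assay, with a stated time of 24 h, tested at 100 ug/mL (on this read-out higher numbers stand for more inhibition of growth at the one concentration tested and lower numbers for less inhibition of growth), compound 1 gives 37.6%, while compound 2 gives 48.5%, a step of a number 10.9 percentage points higher from compound 1 to compound 2 (beyond the scatter). Compound 3 `CC(=O)SCCC(CCCCC(=O)Nc1ccccc1)SC(C)=O` has another core; the difference between the two cores is not broken down here. In this assay compound 3 gives 14.1%, the lowest of the three numbers. Compound 4 `CC(=O)SCCC(CCCCC(=O)Nc1ccccc1Cl)SC(C)=O` is compound 3 with chloro in place of hydrogen on an aromatic carbon. This is the same kind of change as from compound 1 to compound 2, but the place differs: there the chloro sits on a ring with one nitrogen, two atoms from the ring nitrogen and para to a large group; here it sits on a ring of carbon only, ortho to a large group. Compound 4 is expected to show a number 7.9 percentage points higher from compound 3 to compound 4 (within the scatter), resting on a number 10.9 percentage points higher from compound 1 to compound 2 (beyond the scatter), taken smaller as the place differs. Compound 4 is therefore estimated at 22%, between 8% and 38%.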

Compound 4, percent growth inhibition at one concentration: "not active" (no number reported)
The entry for compound 4 holds no number, and the estimate cannot be compared.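

Among the compounds shown here, compound 4 is reported in this assay as not active, without a number, so no step from compound 3 to compound 4 can be read, and no evidence bears on this result. Going by these compounds, how chloro in place of hydrogen acts on the core of compound 3 stays open.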